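Fluoro-methoxyphenyl variation on the ring nitrogen

The compounds below may be only part of what the source reports. "The series", "measured", "known", "first", "only" and "open" are said of these compounds alone.

Measured compounds:
compound 1 `COc1ccccc1N1C(=O)CSC1C(=O)NCCCCc1ccccc1`: 4%
compound 2 `Cc1cccc(N2C(=O)CSC2c2cccc(C(=O)NCCCCc3ccccc3)c2)c1`: 71%
compound 3 `COc1cc(F)ccc1N1C(=O)CSC1c1cccc(C(=O)NCCCCc2ccccc2)c1`: 63%

In a functional assay on 143B cells (Homo sapiens) for inhibition, read by CCK-8 assay, with a stated time of 72 h, tested at 1 uM (a lower number here means less inhibition, a higher number more inhibition at the concentration tested (going by the name of the read-out)), compound 2 gives 71%, the highest of the three numbers. Compound 3 stands nearest to it, with a number 8 percentage points lower from compound 2 to compound 3 (within the scatter). Going by the values given here, compound 1 is furthest away; in this assay compound 1 gives 4%, but compound 1 differs from compound 2 in more than one place, so its value shows only that the shared core alone, without the benzamide-bearing substitution, gives a much lower inhibition number here.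

Compound 4 `COc1c(F)cccc1N1C(=O)CSC1c1cccc(C(=O)NCCCCc2ccccc2)c1` is not yet measured. Relative to compound 2 the change is 3-fluoro-2-methoxyphenyl in place of 3-methylphenyl on an amide-type nitrogen in a ring. Among the compounds with values here, the one measured step that bears on it is the step from compound 2 to compound 3, which also replaces the 3-methylphenyl by a fluoro-methoxyphenyl on the amide-type nitrogen in the ring, differing from the present change only in where the fluorine sits on that phenyl; that step was a number 8 percentage points lower from compound 2 to compound 3 (within the scatter). On this basis no step beyond the scatter is expected for compound 4 in this assay, with the estimated step being a number 6 percentage points lower from compound 2 to compound 4 (within the scatter). Compound 4 is therefore estimated at 65%, with a range from 45% to 80%; a single comparator step leaves this estimate loosely bounded.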

Compound 4, a percentage reported as inhibition, at one concentration (the size of the read-out at that concentration, not a potency): 5%
Estimate against measurement, compound 4: 60 percentage points above, and the stated range ends above it.
By their numbers in this assay, from the lowest: compounds 1 and 4 (each within the scatter of the next); then compounds 3 and 2 (each within the scatter of the next).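

In this assay, fluoro-methoxyphenyl groups on the amide-type nitrogen in a ring are not interchangeable: 3-fluoro-2-methoxyphenyl in place of 3-methylphenyl gives a step beyond the scatter (a number 66 percentage points lower from compound 2 to compound 4 (beyond the scatter)), whereas 4-fluoro-2-methoxyphenyl gave one within it (a number 8 percentage points lower from compound 2 to compound 3 (within the scatter)). Compounds 3 and 4 differ only in where the fluorine sits on the phenyl, and that single difference carries a large step (a number 58 percentage points lower from compound 3 to compound 4 (beyond the scatter)), so at this position the presence of a methoxy group and a fluorine does not by itself set the number; their arrangement on the phenyl matters. Nothing available explains why this arrangement lowers the inhibition number.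

Going by these compounds, it remains open whether the low number belongs to the 3-fluoro substituent alone or to its combination with the 2-methoxy group, which a plain 3-fluorophenyl and a plain 2-methoxyphenyl on the same nitrogen of the shared core would help separate. Also open, on these data alone, is whether a chlorine or a methyl group in place of that fluorine in the 3-fluoro-2-methoxyphenyl group would give a similarly low number.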